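A few compounds are considered here, and "the series" means these few. Any claim that something is new, unique, unknown or untested is made for them only; others in the source may bear on it.

Going by the values given here, in a functional assay on KYSE-450 cells (Homo sapiens) for inhibition, read by MTT assay, with a stated time of 48 h (on this read-out higher numbers stand for weaker inhibition and lower numbers for stronger inhibition), compound 1 (`C/C=C/C(=O)N(Cc1ccc(OC)c(OC)c1)c1cc(OC)c(OC)c(OC)c1`) gives 39100 nM, the highest of the two numbers so far. Compound 2 (`CCC/C=C/C(=O)N(Cc1ccc(OC)c(O)c1)c1cc(OC)c(OC)c(OC)c1`) gives 57 nM. The gap between the two values lies beyond the scatter, but the two compounds differ in more than one place. Compound 3 (`C/C=C/C(=O)N(Cc1ccc(OC)c(F)c1)c1cc(OC)c(OC)c(OC)c1`) has fluoro in place of methoxy on an aromatic carbon, ortho to a methoxy group: fluoro in place of methoxy on an aromatic carbon. Among the compounds with values here, no measured step covers this change. With compound 2 at 57 nM showing that far lower numbers occur in this series, a moderate move toward a lower number in this assay is expected, with wide uncertainty. The expected step is a 7.8-fold lower number from compound 1 to compound 3 (0.89 log units; beyond the scatter). For compound 3 the estimate is 5000 nM, with an expected range of 600 nM to 40000 nM.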

Compound 3, half-maximal inhibitory concentration: 1400 nM
Beside the measured number, compound 3's estimate is 3.6-fold (0.55 log units) above it, within the range that was stated.
By their numbers in this assay, from the lowest: compound 2; then compound 3; then compound 1.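

In this assay, going by these compounds alone, fluoro in place of methoxy on an aromatic carbon, ortho to a methoxy group, gives a 28-fold lower number from compound 1 to compound 3 (1.45 log units; beyond the scatter) and is the first single-place step. This position therefore responds strongly to the group it carries, and a methoxy group there is not required for the lower number. No available evidence gives a cause for this step. Open still is how other groups at this position, such as an amine or a chloro group, compare with fluoro. Also open, from the compounds shown here alone, is whether the step holds in compounds with a longer chain.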